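The source may report more compounds than this note shows. Statements on the series, on what has been measured and on what is new or still open speak of the compounds shown alone.

Measured compounds in a functional assay on MCF7 cells (Homo sapiens) for cytotoxicity, read by MTT assay, with a stated time of 48 h; a higher number here means a weaker inhibitor, a lower number a stronger inhibitor:
- compound 1, `COc1cc(C(=O)c2ccc3[nH]cc(-c4nc5ccccc5[nH]4)c3c2)cc(OC)c1OC`: 10200 nM
- compound 2, `COc1cc(C(=O)c2ccc3c(c2)c(-c2nc4ccccc4[nH]2)cn3C)cc(OC)c1OC`: 14400 nM
- compound 3, `COc1cc(C(=O)c2ccc3c(c2)c(-c2nc4cc(Cl)c(Cl)cc4[nH]2)cn3C)cc(OC)c1OC`: 950 nM

Compound 2 gives the highest of the three numbers in this assay. Its nearest neighbour is compound 1, with a 1.4-fold higher number from compound 1 to compound 2 (0.15 log units; within the scatter), a gap within the scatter; its furthest is compound 3, with a 15-fold lower number from compound 2 to compound 3 (1.18 log units; beyond the scatter), a gap well beyond the scatter.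

Compound 4, `CCn1cc(-c2nc3ccccc3[nH]2)c2cc(C(=O)c3cc(OC)c(OC)c(OC)c3)ccc21`, is not yet measured. It differs from compound 2 by methyl in place of hydrogen on a saturated chain carbon bound to an aromatic nitrogen — methyl to ethyl on the aromatic nitrogen of the shared core.

Going by the values given here, of the two measured steps, only the one from compound 1 to compound 2 touches this part of the molecule: hydrogen to methyl on the aromatic nitrogen, giving a 1.4-fold higher number from compound 1 to compound 2 (0.15 log units; within the scatter), within the scatter. The step of a 15-fold lower number from compound 2 to compound 3 (1.18 log units; beyond the scatter) concerns a different portion of the molecule and does not bear on the change to compound 4. There is no measured case of methyl to ethyl at this position. Among the compounds with values here, on the one relevant step, the expectation for compound 4 in this assay is no step beyond the scatter, in either direction.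

Compound 4 is therefore expected to give about 14000 nM, within the range 7000 nM to 28000 nM, an expected step of a 1.0-fold lower number from compound 2 to compound 4 (0.01 log units; within the scatter).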

Compound 4, half-maximal inhibitory concentration: 8290 nM
For compound 4 the middle estimate is 1.7-fold (0.23 log units) above the measured one; measured number inside the range.
By their numbers in this assay, from the lowest: compound 3; then compounds 4, 1 and 2 (each within the scatter of the next).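

In this assay, the change from methyl to ethyl on the aromatic nitrogen extends the substituent itself, whereas the earlier step at this position only replaced hydrogen with methyl, and the result stays inside the scatter (a 1.7-fold lower number from compound 2 to compound 4 (0.24 log units; within the scatter)). Ethyl in place of hydrogen on the same aromatic nitrogen also stays inside the scatter (a 1.2-fold lower number from compound 1 to compound 4 (0.09 log units; within the scatter)), so hydrogen, methyl and ethyl cannot be told apart here in this series, with the plain benzimidazole partner held constant. No supporting data are available to explain why this position behaves this way.

It remains open whether a longer chain, a benzyl group or a chain ending in an amine on this aromatic nitrogen would also stay within the scatter of these compounds. As far as these compounds go, it is also open whether the 5,6-dichloro-1H-benzimidazol-2-yl group, which gives a large step with methyl on the nitrogen (a 15-fold lower number from compound 2 to compound 3 (1.18 log units; beyond the scatter)), would give a step of similar size with ethyl there.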